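Anilino for hydroxy on a carbonyl carbon: two pairs

The source may hold more compounds than are shown below. What is called first, only, known or untested is meant among the compounds shown, and "the series" means these compounds.

Compound 1 `C=CC1=C(C(=O)O)C(c2ccc(F)cc2)OC1` in a functional assay on QGY7701 cells (Homo sapiens) for cytotoxicity, read by MTT assay, with a stated time of 24 h (a lower number here means a stronger inhibitor, a higher number a weaker inhibitor), gives > 100000 nM, a limit of the assay rather than a number.
Compound 2 `C=CC1=C(C(=O)Nc2ccccc2)C(c2ccc(F)cc2)OC1` in this assay gives 46700 nM.
Compound 3 `C=CC1=C(C(=O)O)C(c2ccc(OC)c(OC)c2)OC1` in this assay gives > 100000 nM, again only a limit of the assay.

The measured pair, compound 1 to compound 2, carries the change (anilino in place of hydroxy on a carbonyl carbon), and the step it made is an at least 2.1-fold lower number from compound 1 to compound 2 (0.33 log units; beyond the scatter). How the core of compound 1 differs from the core of compound 3 is not broken down here. Compound 4 `C=CC1=C(C(=O)Nc2ccccc2)C(c2ccc(OC)c(OC)c2)OC1` arises from compound 3 by the same change, (anilino in place of hydroxy on a carbonyl carbon), at a place described in the same words. What can be said of the series rests on (the limit of > 100000 nM in this assay, at which 2 of the 3 values shown sit), so the first step is known only as a lower bound. From compound 3 to compound 4 a step of an at least 2.0-fold lower number from compound 3 to compound 4 (0.30 log units; that floor lies within the scatter) is expected, resting on the measured step of an at least 2.1-fold lower number from compound 1 to compound 2 (0.33 log units; beyond the scatter). Compound 4 is thus estimated at 50000 nM, likely from 20000 nM to 120000 nM.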

Compound 4, half-maximal inhibitory concentration: > 100000 nM
Compound 4 was reported as a limit (the forecaster's own chance of this, stated with the estimate: 30%); middle value at least 2.0-fold (0.30 log units) away from the limit.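

No step can be read from compound 3 to compound 4 in this assay, as both results are limits of the assay: the limit of > 100000 nM in this assay, at which 3 of the 4 values shown sit.

From the compounds shown here alone, whether anilino in place of hydroxy acts on the core of compound 3 as it does on the core of compound 1 remains open.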